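The source may report more compounds than this note shows. Statements on the series, on what has been measured and on what is new or still open speak of the compounds shown alone.

Two compounds have so far been measured in a functional assay on Ehrlich cells (Mus musculus) for cytotoxicity, tested at 100 ug/mL; a higher number here means a stronger effect of the compound at the concentration tested, a lower number a weaker effect:

compound 1 `COc1cc(N2C(N)=C(C#N)C(c3ccc(OC)c4ccccc34)C3=C2CC(C)(C)CC3=O)cc(OC)c1OC` gives 40%
compound 2 `COc1cc(N2C(N)=C(C#N)C(c3ccccc3)C3=C2CC(C)(C)CC3=O)cc(OC)c1OC` gives 10%

Compound 2 stands at the lower of these two numbers. Among the compounds with values here, its only neighbour is compound 1, and the single measured step, a number 30 percentage points lower from compound 1 to compound 2 (beyond the scatter), separates them: it swaps one aryl group for another on the saturated ring carbon.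

Compound 3 `COc1cc(N2C(N)=C(C#N)C(c3ccc(O)cc3)C3=C2CC(C)(C)CC3=O)cc(OC)c1OC` differs from compound 2 by hydroxy in place of hydrogen on an aromatic carbon, placed on an aromatic carbon of a six-membered aromatic ring of carbon only, para to a large group. Within the data shown here, the step from compound 1 to compound 2 exchanged the whole aryl group and so does not speak directly to a hydroxy added to phenyl; no measured pair shows that change. Lacking such a pair, the step of a number 5 percentage points higher from compound 2 to compound 3 (within the scatter) is expected to stay within the scatter. Compound 3 is therefore estimated at 15%, with a range from 0% to 40%.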

Compound 3, a percentage reported as activity, at one concentration (the size of the read-out at that concentration, not a potency): 100%
The estimate for compound 3 lay 85 percentage points below the measured number; the measured number lies above the stated range.
By their numbers in this assay, from the lowest: compound 2; then compound 1; then compound 3.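

In this assay, the aryl group on the saturated ring carbon turns out to respond strongly to a very small change: adding hydroxy to the phenyl ring, para to a large group, gives a number 90 percentage points higher from compound 2 to compound 3 (beyond the scatter), a larger step than the earlier exchange of one whole aryl group for another. The 4-hydroxyphenyl group also outdoes the 4-methoxynaphthalen-1-yl group, with a number 60 percentage points higher from compound 1 to compound 3 (beyond the scatter), so compound 3 stands clearly above both others and the larger aryl group no longer marks the higher number. Nothing at hand bears on why the hydroxy has this effect.

The compounds shown leave open whether a methoxy, an amine or a carboxylic acid in place of this hydroxy would give a similar number. They also leave open whether a hydroxy elsewhere on the phenyl ring would do the same.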